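A few compounds are considered here, and "the series" means these few. Any claim that something is new, unique, unknown or untested is made for them only; others in the source may bear on it.

Three amides sharing one core have been measured. Compound 1 `Cc1ccc(NC(=O)c2c(O)c3cccnc3n(-c3ccccc3)c2=O)cc1` gives 2.2% in a functional assay on the whole organism for inhibition, with Rattus norvegicus as the target, read by cytopathic effect and paw edema, at a dose of 100 mg/kg by the oral route; a lower number here means less inhibition, a higher number more inhibition at the dose given (going by the name of the read-out). Compound 2 `O=C(Nc1ccc(Cl)cc1)c1c(O)c2cccnc2n(-c2ccccc2)c1=O` gives 2.5% in this assay, and compound 3 `O=C(Nc1ccc([N+](=O)[O-])cc1)c1c(O)c2cccnc2n(-c2ccccc2)c1=O` gives -25.8% in this assay. Compound 3 stands lowest of the three numbers; the nearest value is that of compound 1 and the furthest that of compound 2, both separated from it beyond the scatter. Between compound 1 and compound 2 the change is a number 0.3 percentage points higher from compound 1 to compound 2 (within the scatter), so those two values cannot be ordered.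

The next step goes to compound 4 `COc1cccc(NC(=O)c2c(O)c3cccnc3n(-c3ccccc3)c2=O)c1`. Its difference from compound 3 is 3-methoxyphenyl in place of 4-nitrophenyl on an amide-type nitrogen.

For the measured compounds named here, the steps that bear on it are those that brought the nitro group in: a number 28 percentage points lower from compound 1 to compound 3 (beyond the scatter) and a number 28.3 percentage points lower from compound 2 to compound 3 (beyond the scatter). Going by the values given here, both point the same way, and the present step takes the nitro group out again, replacing it with a group whose effect has no direct precedent here; the 3-methoxyphenyl group has not been measured. The reasonable expectation is therefore a reversal of the earlier fall, with the value returning toward the level of compound 1 and compound 2, expected as a number 28.8 percentage points higher from compound 3 to compound 4 (beyond the scatter).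

Compound 4 is estimated at 3%, with a range from -12% to 18%.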

Compound 4, a percentage reported as inhibition, in the whole organism at one dose (the size of the read-out at that dose, not a potency): 20.7%
For compound 4 the middle estimate is 17.7 percentage points below the measured one; the whole stated range lies below it.
By their numbers in this assay, from the lowest: compound 3; then compounds 1 and 2 (each within the scatter of the next); then compound 4.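

In this assay, for the compounds shown here, the aryl group on the amide-type nitrogen can move the read-out above the level shared by compound 1 and compound 2, not only below it: the series shows a number 18.5 percentage points higher from compound 1 to compound 4 (beyond the scatter) and a number 18.2 percentage points higher from compound 2 to compound 4 (beyond the scatter) as well as a number 46.5 percentage points higher from compound 3 to compound 4 (beyond the scatter) in the widest step so far, and compound 4 now stands highest of the four. The new group differs from the earlier ones in both its substituent and its printed position, since 3-methoxyphenyl replaces groups named 4-methylphenyl, 4-chlorophenyl and 4-nitrophenyl, so the rise cannot be assigned to the methoxy group alone or to the 3-position alone. No measurement is available that would account for these steps.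

A 4-methoxyphenyl amide and a 3-chlorophenyl amide would be the direct tests that separate substituent from position, and an amine or a carboxylic acid on the same phenyl ring would show how far the range extends. These are single-dose percentages, so the compounds shown leave open whether the order would hold at other doses.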